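The compounds below may be only part of what the source reports. "The series", "measured", "known", "first", "only" and "open" are said of these compounds alone.

In a functional assay on HCT-116 cells (Homo sapiens) for cytotoxicity, read by MTT assay, with a stated time of 72 h (on this read-out lower numbers stand for stronger inhibition and higher numbers for weaker inhibition), compound 3 `O=C1c2c[n+]([O-])c3ccccc3c2C(=O)c2c1c1ccccc1n2Cc1cn(C[C@H](O)CO)nn1` gives 400 nM, the second highest of the three numbers recorded. Its nearest neighbour is compound 1 `CN(C)CCCCCn1c2c(c3ccccc31)C(=O)c1c[n+]([O-])c3ccccc3c1C2=O`, which gives 470 nM; the step of a 1.2-fold lower number from compound 1 to compound 3 (0.07 log units; within the scatter) lies within the scatter. Its furthest neighbour is compound 2 `O=C1c2c[n+]([O-])c3ccccc3c2C(=O)c2c1c1ccccc1n2Cc1cn([C@@H]2C[C@H](O)[C@@H](CO)O2)nn1`, which gives 50 nM; the step of an 8.0-fold higher number from compound 2 to compound 3 (0.90 log units; beyond the scatter) is beyond the scatter.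

Compound 4 `O=C1c2c[n+]([O-])c3ccccc3c2C(=O)c2c1c1ccccc1n2CCN1CCCCC1` is the next compound to be measured. Relative to compound 3 the change is (piperidin-1-yl)methyl in place of 1-(2,3-dihydroxypropyl)-1H-1,2,3-triazol-4-yl on a saturated chain carbon bound to an aromatic nitrogen.

Among the measured compounds shown here, only one measured step bears on this change, the one from compound 1 to compound 3, in which a 4-(dimethylamino)butyl chain on the same saturated carbon was traded for the triazolyl group, with a 1.2-fold lower number from compound 1 to compound 3 (0.07 log units; within the scatter) staying within the scatter. Compound 4 returns to a chain carrying a saturated amine, 2-(piperidin-1-yl)ethyl, so no step beyond the scatter is expected. Compound 4 is estimated at 450 nM, with a range from 150 nM to 1400 nM, amounting to an expected step of a 1.1-fold higher number from compound 3 to compound 4 (0.05 log units; within the scatter).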

Compound 4, half-maximal inhibitory concentration: 780 nM
For compound 4 the middle estimate is 1.7-fold (0.24 log units) below the measured one; the range from low to high includes it.
By their numbers in this assay, from the lowest: compound 2; then compounds 3, 1 and 4 (each within the scatter of the next).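

In this assay the exchange on this saturated chain carbon bound to an aromatic nitrogen gives a 2.0-fold higher number from compound 3 to compound 4 (0.29 log units; within the scatter) even though the group that enters has no aromatic ring, no hydrogen-bond donors and no defined stereocentre. The two chains that carry a saturated amine also cannot be told apart, with a 1.7-fold higher number from compound 1 to compound 4 (0.22 log units; within the scatter) when piperidin-1-yl stands in place of 3-(dimethylamino)propyl, so across compounds 1, 3 and 4 this position has so far tolerated quite different groups with no step beyond the scatter. Nothing available here explains these results.

The compounds shown leave open whether a morpholine in place of the piperidine, or a longer chain ending in piperidin-1-yl, would stay within the scatter of these values. They also leave open whether a carboxylic acid at this position would do so, or whether any group on this chain would match compound 2 at 50 nM in this read-out.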